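Chloro in place of hydrogen: compound 3 to compound 4

This account rests on a few compounds, and the source may have more. Where it says the series, first, only, none or still open, it means among the compounds named here.

In a functional assay on HeLa cells (Homo sapiens) for inhibition (on this read-out higher numbers stand for weaker inhibition and lower numbers for stronger inhibition), compound 3 (`O=C1O/C(=C\Cn2ccc(=O)[nH]c2=O)C(OCc2ccccc2)=C1OCc1ccccc1`) reads 50000 nM, compound 1 (`O=C1O/C(=C\Cn2cc(C(F)(F)F)c(=O)[nH]c2=O)C(OCc2ccccc2)=C1OCc1ccccc1`) reads 60000 nM and compound 2 (`O=C1O/C(=C\Cn2cc(I)c(=O)[nH]c2=O)C(OCc2ccccc2)=C1OCc1ccccc1`) reads 40000 nM, so compound 3 stands within the scatter of both others.

Compound 4 (`O=C1O/C(=C\Cn2cc(Cl)c(=O)[nH]c2=O)C(OCc2ccccc2)=C1OCc1ccccc1`) has chloro in place of hydrogen on an aromatic carbon, and the counted change is chloro in place of hydrogen on an aromatic carbon for this open step.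

For the measured compounds named here, three measured steps bear on it, all at this same carbon. Iodo, the other halogen here, gives way to hydrogen in a 1.3-fold higher number from compound 2 to compound 3 (0.10 log units; within the scatter), and trifluoromethyl gives way to hydrogen in a 1.2-fold lower number from compound 1 to compound 3 (0.08 log units; within the scatter). The exchange of the two groups gives a 1.5-fold lower number from compound 1 to compound 2 (0.18 log units; within the scatter). All three stay within the scatter, so no step beyond the scatter is expected in this assay from chloro.

The estimated step is a 1.1-fold lower number from compound 3 to compound 4 (0.05 log units; within the scatter) and would be indistinguishable from no change.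

For compound 4 the expected value is 45000 nM, with an estimated range from 25000 nM to 80000 nM as its span.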

Compound 4, half-maximal inhibitory concentration: 30000 nM
Compound 4: middle estimate off by 1.5-fold (0.18 log units), on the high side; the measured number falls inside the stated range.
By their numbers in this assay, from the lowest: compounds 4, 2, 3 and 1 (each within the scatter of the next).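

Chloro is the fourth group at this aromatic carbon in this assay, and it too gives no step that can be separated from the scatter, whether set against hydrogen (a 1.7-fold lower number from compound 3 to compound 4 (0.22 log units; within the scatter)), iodo (a 1.3-fold lower number from compound 2 to compound 4 (0.12 log units; within the scatter)) or trifluoromethyl (a 2.0-fold lower number from compound 1 to compound 4 (0.30 log units; within the scatter)). For the compounds shown here, with chloro added, hydrogen and the three larger groups at this carbon still cannot be told apart in this assay, so the series shows no dependence on this position so far. No measured information on the compounds bears on this result.

The compounds shown leave open whether an amine, a carboxylic acid or a longer alkyl chain at this carbon would give a step beyond the scatter. They also leave open what replacing the benzyloxy groups on the shared core would do.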